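A few compounds are considered here, and "the series" means these few. Any claim that something is new, unique, unknown or untested is made for them only; others in the source may bear on it.

Measured compounds and their values in a functional assay on NCI-H23 cells (Homo sapiens) for inhibition, read by sulforhodamine B assay, with a stated time of 48 h; a higher number here means a weaker inhibitor of growth, a lower number a stronger inhibitor of growth:
compound 1 `O=CN1CCN(c2ccc(Cl)cc2)C1=S` gives 23000 nM
compound 2 `COc1cc(C(=O)N2CCN(C=O)C2=S)cc(OC)c1OC` gives 25900 nM
compound 3 `O=CN1CCN(C(=O)c2ccco2)C1=S` gives 16700 nM

These three compounds share a core and have all been tested in this assay. Compound 1 stands second highest of the three numbers. Its nearest neighbour is compound 2, whose number is only slightly higher and within the scatter, and its furthest is compound 3, whose gap to compound 1 also lies within the scatter. On these numbers, then, the three compounds cannot be told apart.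

Compound 4 `O=CN1CCN(c2ccc(Cl)c(Cl)c2)C1=S` has not yet been measured. It differs from compound 1 in one place: chloro in place of hydrogen on an aromatic carbon. Among the measured compounds shown here, no two of the measured compounds differ in just one place, so there is no measured step of this kind to lean on. The step from compound 1 to compound 4 is expected to be small, a 1.4-fold lower number from compound 1 to compound 4 (0.13 log units; within the scatter), toward a somewhat lower number but not beyond the scatter. Compound 4 is therefore estimated at 17000 nM, with a range from 7000 nM to 45000 nM.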

Compound 4, concentration for 50% growth inhibition: 20900 nM
Compound 4: middle estimate off by 1.2-fold (0.09 log units), on the low side; low and high end bracket the measured number.
By their numbers in this assay, from the lowest: compounds 3, 4, 1 and 2 (each within the scatter of the next).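

In this assay the series now has its first measured change in a single place, chloro in place of hydrogen on an aromatic carbon, and the step is a 1.1-fold lower number from compound 1 to compound 4 (0.04 log units; within the scatter) and lies within the scatter. At this carbon, ortho to a chloro group and meta to a group of 8 heavy atoms, the added chloro therefore gives no change that can be told from assay scatter, which the three earlier compounds could not show because none differs from another in just one place. No measurement of any other property of these compounds bears on this result.

On these data alone, whether an amine or a carboxylic acid on this same carbon would shift the number beyond the scatter remains open. Also open, as far as these compounds go, is how the number responds when hydrogen or a longer chain replaces the original chloro of compound 1.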